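The source may report more compounds than this note shows. Statements on the series, on what has been measured and on what is new or still open speak of the compounds shown alone.

Measured so far:
- compound 1, `CNC(=O)C(C)(C)C(c1ccc(Nc2ccccc2)cc1)n1ccnc1`: 200 nM
- compound 2, `CCNC(=O)C(C)(C)C(c1ccc(Nc2ccccc2)cc1)n1ccnc1`: 250 nM

In an assay on microsomes from MCF7 cells for inhibition of cytochrome P450 26A1 (Homo sapiens), read by scintillation counting, with a stated time of 1 h (a higher number here means a weaker inhibitor, a lower number a stronger inhibitor), compound 1 gives 200 nM, and compound 2 gives 250 nM. For the measured compounds named here, the one measured step, a 1.3-fold higher number from compound 1 to compound 2 (0.10 log units; within the scatter), lies within the scatter, so compound 1 and compound 2 are not told apart by these numbers; compound 1 simply serves as the anchor for the next comparison.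

Compound 3, `CNC(=O)C(C)(C)C(c1ccc(Nc2ccc(OC)cc2)cc1)n1ccnc1`, differs from compound 1 by methoxy in place of hydrogen on an aromatic carbon. Going by the values given here, the step from compound 1 to compound 2 sits on the amide side of the shared core and leaves the anilino ring untouched, so it does not bear on this change; no measured pair alters that ring. There is therefore nothing in the data to call a direction, and the working expectation is a step of no particular size beyond the scatter, with a wider range than usual to reflect the absence of a precedent.

For compound 3 the estimate in this assay is 200 nM, spanning 60 nM to 700 nM. The expected step is no change at the digits printed from compound 1 to compound 3 (within the scatter).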

Compound 3, half-maximal inhibitory concentration: > 1000 nM
Compound 3 ended at the assay's limit; the forecaster's own chance of this, stated with the estimate: 5%; middle value at least 5.0-fold (0.69 log units) from the limit.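

In this assay, the anilino ring of the shared core now has its first measured change, and that change matters: methoxy in place of hydrogen on an aromatic carbon, para to a large group, gives an at least 5.0-fold higher number from compound 1 to compound 3 (0.69 log units; beyond the scatter). The reading for compound 3 is a limit of the assay and not a number: the limit of > 1000 nM in this assay, at which 1 of the 3 values shown sits.

The amide-side change, a 1.3-fold higher number from compound 1 to compound 2 (0.10 log units; within the scatter), did not separate its two compounds, whereas this single ring change does, so this position responds to substitution at least in the pair shown, with the methoxy compound the weaker inhibitor.

One substituent at one position cannot show whether the weaker reading belongs to methoxy specifically or to any group placed there; fluorine, chlorine, methyl or hydroxyl at the same carbon would begin to separate those possibilities. The compounds shown also leave open how methoxy would read on the other carbons of that ring, and whether the same change would carry over to compound 2.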